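Dropping One Trifluoromethyl Group from a Diaryl Urea

A few compounds are considered here, and "the series" means these few. Any claim that something is new, unique, unknown or untested is made for them only; others in the source may bear on it.

Measured compounds:
Compound 1: `COc1cc(-c2nn(-c3cccc(NC(=O)Nc4cc(C(F)(F)F)cc(C(F)(F)F)c4)c3)cc2-c2ccncc2)ccc1Cl` — 1370 nM
Compound 2: `O=C(Nc1cccc(-n2cc(-c3ccncc3)c(-c3ccc(Cl)c(O)c3)n2)c1)Nc1ccc(Cl)c(Cl)c1` — 9680 nM

Of the compounds shown here, two sharing a core have been tested in a functional assay on U-251 cells (Homo sapiens) for inhibition, read by sulforhodamine B assay, with a stated time of 48 h; on this read-out lower numbers stand for stronger inhibition of growth and higher numbers for weaker inhibition of growth. Compound 1 gives the lowest of the two numbers, with 1370 nM; compound 2 gives 9680 nM, a higher number, and the gap between the two lies beyond the usual scatter of this assay.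

Compound 3, `COc1cc(-c2nn(-c3cccc(NC(=O)Nc4cccc(C(F)(F)F)c4)c3)cc2-c2ccncc2)ccc1Cl`, has not yet been measured. It differs from compound 1 in one place only: hydrogen in place of trifluoromethyl on an aromatic carbon. The group that leaves sits on the outer ring of the urea, meta to a trifluoromethyl group that stays behind.

For the measured compounds named here, with no measured pair showing this exact change, the expectation rests on compound 1 alone. A modest step towards weaker growth inhibition is expected, so that the change from compound 1 to compound 3 is estimated as a 2.6-fold higher number from compound 1 to compound 3 (0.41 log units; beyond the scatter). Compound 3 is therefore expected to give about 3500 nM in this assay , within a range from 1200 nM to 10000 nM.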

Compound 3, concentration for total growth inhibition: 1370 nM
Estimate against measurement, compound 3: 2.6-fold (0.41 log units) above; low and high end bracket the measured number.
By their numbers in this assay, from the lowest: compounds 1 and 3 (each within the scatter of the next); then compound 2.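

In this assay, putting hydrogen in place of trifluoromethyl on an aromatic carbon, meta to a trifluoromethyl group that stays, gives no change at the digits printed from compound 1 to compound 3 (within the scatter). For this pair, then, the second trifluoromethyl group can go, with its four heavy atoms, and the measured growth inhibition stays within the scatter, so at this position that group is not needed to keep the number where it stands. Nothing measured here explains why the change is tolerated.

Still open, from the compounds shown here alone, is whether the trifluoromethyl group that stays can also be removed, and whether an amine or a carboxylic acid at this position would be tolerated as well. This single pair also says nothing about how the same change would act on a compound with a different substitution pattern, such as compound 2.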